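Diethylamino for pyrrolidin-1-yl at the assay limit

The compounds below may be only part of what the source reports. "The series", "measured", "known", "first", "only" and "open" are said of these compounds alone.

In an ADME assay on HaCaT cells (Homo sapiens) for antiproliferative activity, with a stated time of 48 h (on this read-out lower numbers stand for stronger inhibition and higher numbers for weaker inhibition), compound 1 (`CC(=O)c1ccc(-c2ccc(N3CCCC3)nn2)cc1`) gives > 25000 nM which is a limit and not a number. Compound 1 therefore has no readable position in the series, and the other two measured values offer no better reference. Compound 2 (`CCN(CC)c1ccc(-c2cccc(Cl)c2)nn1`) already carries diethylamino and gives > 25000 nM which is also a limit. Compound 3 (`CCN(CC)c1ccc(-c2cccc(C(F)(F)F)c2)nn1`) carries diethylamino too and gives > 25000 nM which is again a limit. The measured set thus rests on the limit of > 25000 nM in this assay, at which 3 of the 3 values shown sit, and holds no number to compare.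

Compound 4 (`CCN(CC)c1ccc(-c2ccc(C(C)=O)cc2)nn1`) differs from compound 1 in one place, with diethylamino in place of pyrrolidin-1-yl on an aromatic carbon and the rest of the core unchanged. Within the data shown here, the one measured step is a step that the two limits leave unreadable from compound 2 to compound 3 and it concerns trifluoromethyl in place of chloro on an aromatic carbon, so it offers no size to carry over. No step beyond the scatter is therefore expected in this assay and no direction can be assigned. The estimated step is a step that the limit leaves unreadable from compound 1 to compound 4 and it should be read with that caution. For compound 4 the estimated value is 30000 nM with an expected range from 12000 nM to 60000 nM and a report of only a limit is the likeliest outcome.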

Compound 4, half-maximal inhibitory concentration: 20000 nM
Compound 4: middle estimate off by 1.5-fold (0.18 log units), on the high side; measured number inside the range.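

In this assay, among these compounds, diethylamino in place of pyrrolidin-1-yl, on the aromatic carbon next to the ring nitrogen, gives an at least 1.2-fold lower number from compound 1 to compound 4 (0.09 log units; that floor lies within the scatter), the first step with a direction and a floor, and compound 4 is the first compound with a readable number. The two groups match in the counts of heavy atoms, donors and acceptors and differ in that pyrrolidin-1-yl has a ring and diethylamino has none, so the open chain at this position is at least compatible with a measurable value. The true size of the step stays unknown, and the direction carries little weight, because one end of the step is a limit and the floor lies within the scatter: the limit of > 25000 nM in this assay, at which 3 of the 4 values shown sit.

Open, on these data alone, is whether longer chains on the amine, such as dipropylamino, or another cyclic amine, such as piperidin-1-yl or morpholin-4-yl, would give numbers clearly away from this level. Also open, as far as these compounds go, is whether a carboxylic acid or a primary amide in place of the acetyl group of compound 4 would move the value beyond the scatter.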